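The source may report more compounds than this note shows. Statements on the series, on what has been measured and on what is new or still open speak of the compounds shown alone.

Working notes on the aryl series. Compound 1 `CSc1nc(NCCCCNc2ccnc3cc(Cl)ccc23)c(C#N)c(-c2ccccc2)n1` carries the plain phenyl group; in an ADME assay on HeLa cells (Homo sapiens) for inhibition, read by cell counting (a lower number here means a stronger inhibitor, a higher number a weaker inhibitor), compound 1 gives 8500 nM. Compound 2 `CSc1nc(NCCCCNc2ccnc3cc(Cl)ccc23)c(C#N)c(-c2cccc([N+](=O)[O-])c2)n1` carries the 3-nitrophenyl group, and in this assay compound 2 gives 1100 nM. Compound 3 `COc1cc(-c2nc(SC)nc(NCCCCNc3ccnc4cc(Cl)ccc34)c2C#N)cc(OC)c1OC` carries the 3,4,5-trimethoxyphenyl group; in this assay compound 3 gives 3400 nM, the second highest of the three numbers. Its position is set by a 2.5-fold lower number from compound 1 to compound 3 (0.40 log units; beyond the scatter) and by a 3.1-fold higher number from compound 2 to compound 3 (0.49 log units; beyond the scatter).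

Compound 4 `CSc1nc(NCCCCNc2ccnc3cc(Cl)ccc23)c(C#N)c(-c2ccc(C)cc2)n1` differs from compound 3 in one place: 4-methylphenyl in place of 3,4,5-trimethoxyphenyl on an aromatic carbon.

For the measured compounds named here, no measured step swaps these two aryl groups directly. The step that comes closest is the one from phenyl, a 2.5-fold lower number from compound 1 to compound 3 (0.40 log units; beyond the scatter); the other aryl step, a 7.7-fold lower number from compound 1 to compound 2 (0.89 log units; beyond the scatter), shows that a single substituent on this ring can move the number further. The 4-methylphenyl group of compound 4 resembles the plain phenyl of compound 1 more than it resembles the trimethoxyphenyl of compound 3, so the number for compound 4 is expected to move back toward that of compound 1. A modest upward step is therefore expected for compound 4, a 1.8-fold higher number from compound 3 to compound 4 (0.25 log units; within the scatter). The estimate for compound 4 in this assay is 6000 nM, with a range from 2500 nM to 15000 nM.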

Compound 4, half-maximal inhibitory concentration: 5000 nM
Estimate against measurement, compound 4: 1.2-fold (0.08 log units) above, within the range that was stated.
By their numbers in this assay, from the lowest: compound 2; then compounds 3, 4 and 1 (each within the scatter of the next, the first and the last beyond it).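

At this position, next to the ring nitrogen and ortho to a cyano group, 4-methylphenyl with 7 heavy atoms and no hydrogen-bond acceptors cannot be told apart from 3,4,5-trimethoxyphenyl with 12 heavy atoms and 3 hydrogen-bond acceptors in this assay, a 1.5-fold higher number from compound 3 to compound 4 (0.17 log units; within the scatter), and methyl in place of hydrogen on the phenyl ring also stays unresolved, a 1.7-fold lower number from compound 1 to compound 4 (0.23 log units; within the scatter). The 3-nitrophenyl group of compound 2 is the one that remains separated from the new compound, a 4.5-fold higher number from compound 2 to compound 4 (0.66 log units; beyond the scatter), so among the four aryl groups shown, a substituent on this ring does not in itself give a number apart from the others: compound 3 and compound 4 carry substituents and remain within the scatter of their neighbours, while compound 2 does not. No measured evidence accounts for the separate position of compound 2.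

Going by these compounds, whether that position belongs to the nitro group itself or to its place on the ring stays open, and a 4-nitrophenyl group would bear on this. On these data alone, how a 3-aminophenyl or a 3-carboxyphenyl group would compare with compound 2 at this position also remains open.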